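Changing the aromatic group on the carbonyl of compound 2

A few compounds are considered here, and "the series" means these few. Any claim that something is new, unique, unknown or untested is made for them only; others in the source may bear on it.

In an in vitro ADME assay on microsomes from liver (Homo sapiens) for metabolic stability (on this read-out higher numbers stand for fast clearance and lower numbers for slow clearance), compound 1 `O=C(C=C1CCN(C(=O)c2ccc(F)cc2)CC1)N[C@@H]1CCN(Cc2ccc3cc(F)ccc3c2)C1` gives 237 mL/min/kg and compound 2 `COc1ccc(C(=O)N2CCC(=CC(=O)N[C@@H]3CCN(Cc4ccc5cc(F)ccc5c4)C3)CC2)cc1` gives 252 mL/min/kg, so compound 2 stands level with compound 1 within the usual scatter. Compound 3 `Cc1ccc(C(=O)N2CCC(=CC(=O)N[C@@H]3CCN(Cc4ccc5cc(F)ccc5c4)C3)CC2)c(O)c1` differs from compound 2 as follows: 2-hydroxy-4-methylphenyl in place of 4-methoxyphenyl on a carbonyl carbon. Among the compounds with values here, the only measured step, methoxy in place of fluoro on an aromatic carbon, is a 1.1-fold higher number from compound 1 to compound 2 (0.03 log units; within the scatter). Within the data shown here, no measured step tests the hydroxy or methyl group, so that small step is weak guidance. The expected step is a 1.1-fold lower number from compound 2 to compound 3 (0.02 log units; within the scatter), with no change beyond the scatter expected. Compound 3 is estimated at 240 mL/min/kg, with an expected range of 130 mL/min/kg to 430 mL/min/kg.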

Compound 3, clearance: 156 mL/min/kg
Estimate against measurement, compound 3: 1.5-fold (0.19 log units) above; the range from low to high includes it.
By their numbers in this assay, from the lowest: compounds 3, 1 and 2 (each within the scatter of the next).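

In this assay, 2-hydroxy-4-methylphenyl in place of 4-methoxyphenyl on the carbonyl carbon gives a 1.6-fold lower number from compound 2 to compound 3 (0.21 log units; within the scatter) and, in place of 4-fluorophenyl, gives a 1.5-fold lower number from compound 1 to compound 3 (0.18 log units; within the scatter) here too. This position therefore takes an aromatic group with a hydrogen-bond donor without a step beyond the scatter, so all three compounds stand level. Nothing measured here bears on why the numbers fall as they do. The hydroxy and methyl groups arrive together, so their separate shares cannot be told. As far as these compounds go, what an amine or a carboxylic acid on this aromatic ring would do to clearance remains open.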